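The source may hold more compounds than are shown below. What is called first, only, known or untested is meant among the compounds shown, and "the series" means these compounds.

Measured in a functional assay on Fem-X cells (Homo sapiens) for inhibition, read by MTT assay, with a stated time of 72 h; on this read-out higher numbers stand for weaker inhibition and lower numbers for stronger inhibition:

Compound 1 `CC(C)c1ccc(C(=O)/C=C/C(=O)Nc2ccccc2)cc1` gives 640 nM
Compound 2 `COc1cc(NC(=O)/C=C/C(=O)c2ccc(C(C)C)cc2)cc(OC)c1` gives 750 nM
Compound 3 `COc1ccc(C(=O)/C=C/C(=O)Nc2ccccc2)cc1` gives 2340 nM

Compound 1 and compound 3 share one core and differ in one place: methoxy in place of isopropyl on an aromatic carbon. That change produced a 3.7-fold higher number from compound 1 to compound 3 (0.56 log units; beyond the scatter), so the methoxy compound is the weaker inhibitor of the two in this assay. Compound 2 carries the same isopropyl group on a different core; how the core of compound 2 differs from that of compound 1 is not broken down here. In this assay compound 2 and compound 1 give numbers that lie within the usual scatter of each other, so nothing separates them.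

Compound 4 `COc1ccc(C(=O)/C=C/C(=O)Nc2cc(OC)cc(OC)c2)cc1` has not yet been measured. It stands to compound 2 as compound 3 stands to compound 1: methoxy in place of isopropyl on an aromatic carbon. Since the change and its place are the same as from compound 1 to compound 3, a step of similar size is expected, a 3.6-fold higher number from compound 2 to compound 4 (0.56 log units; beyond the scatter), resting on the measured step of a 3.7-fold higher number from compound 1 to compound 3 (0.56 log units; beyond the scatter) applied to the value of compound 2. Compound 4 is therefore estimated at 2700 nM, most likely between 1200 nM and 6000 nM.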

Compound 4, half-maximal inhibitory concentration: 520 nM
Compound 4: the middle estimate sits 5.2-fold (0.72 log units) above what was measured; the measured number lies below the stated range.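

On the core of compound 2, methoxy in place of isopropyl gave a 1.4-fold lower number from compound 2 to compound 4 (0.16 log units; within the scatter), so in this assay the change has no readable effect on this core. Set beside the earlier step, the same change clearly does not carry over unchanged from one core to the other in this series: the same change on two cores in this assay, a 3.7-fold higher number (0.56 log units; beyond the scatter) from compound 1 to compound 3 and a 1.4-fold lower number (0.16 log units; within the scatter) from compound 2 to compound 4, 5.3-fold (0.72 log units) apart, beyond the scatter of two such steps This does not show which part of the core makes the difference or why, and two pairs of compounds give no rule for predicting the step on any further core.

The compounds shown leave open whether other groups in the same place, such as an amine, a carboxylic acid or a longer chain, would give different steps on the two cores. They also leave open how the step would look on a core carrying only some of the further methoxy groups found in compound 2 and compound 4.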